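Swapping the aryl group on the shared core: compound 4

The source may report more compounds than this note shows. Statements on the series, on what has been measured and on what is new or still open speak of the compounds shown alone.

Of the compounds shown here, three of one series have been measured in an ADME assay on Huh7.5.1 cells (Homo sapiens) for cytotoxicity, read by ATP content, with a stated time of 48 h; on this read-out higher numbers stand for lower toxicity in this test and lower numbers for higher toxicity in this test. Compound 1 `Cc1ccccc1-c1nc(CN2CCC(C(=O)NCCCN3CCC(C)CC3)CC2)c(C)o1` gives 12300 nM, compound 2 `Cc1oc(-c2ccc(F)cc2)nc1CN1CCC(C(=O)NCCCN2C[C@H](C)C[C@H](C)C2)CC1` gives 12800 nM, and compound 3 `Cc1ccccc1-c1nc(CN2CCC(C(=O)NCCCCN3C[C@H](C)C[C@H](C)C3)CC2)c(C)o1` gives 23100 nM. Compound 2 stands second highest of the three, with compound 1 nearest and compound 3 furthest, all within the scatter. Among the measured compounds shown here, the one measured step, a 1.9-fold higher number from compound 1 to compound 3 (0.27 log units; within the scatter), is likewise within the scatter. Compound 4 `COc1cccc(Cl)c1-c1nc(CN2CCC(C(=O)NCCCN3C[C@H](C)C[C@H](C)C3)CC2)c(C)o1` differs from compound 2 at one place: 2-chloro-6-methoxyphenyl in place of 4-fluorophenyl on an aromatic carbon. For the measured compounds named here, no measured step touches this aromatic carbon, so there is no step to carry over; the measured numbers span a narrow band, and a step within the scatter is expected, a 1.1-fold lower number from compound 2 to compound 4 (0.03 log units; within the scatter). Compound 4 is therefore estimated at 12000 nM, with a range from 6000 nM to 25000 nM.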

Compound 4, half-maximal cytotoxic concentration: 15800 nM
Compound 4: the middle estimate sits 1.3-fold (0.12 log units) below what was measured, and the stated range covers the measured number.
By their numbers in this assay, from the lowest: compounds 1, 2, 4 and 3 (each within the scatter of the next).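

In this assay, among the compounds shown here, placing 2-chloro-6-methoxyphenyl in place of 4-fluorophenyl on this aromatic carbon gives a 1.2-fold higher number from compound 2 to compound 4 (0.09 log units; within the scatter) as the first measured step at this position. A group of 9 heavy atoms with 1 hydrogen-bond acceptor thus replaces one of 7 heavy atoms with 0, and the two compounds remain within the scatter of each other. Nothing available gives a reason for this result.

On these data alone, it remains open how 2-chlorophenyl or 2-methoxyphenyl alone would read at this position. Also open, as far as these compounds go, is whether an aryl group carrying an amine or a carboxylic acid would stay within the scatter.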